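Pyridin-2-yl on the amine nitrogen: compound 2 to compound 3

The source may hold more compounds than are shown below. What is called first, only, known or untested is meant among the compounds shown, and "the series" means these compounds.

Among the compounds with values here, in a functional assay on CWR22R cells (Homo sapiens) for antiproliferative activity, read by CCK-8 assay, with a stated time of 6 days (on this read-out higher numbers stand for weaker inhibition and lower numbers for stronger inhibition), compound 1 (`CC(O)c1ccc(C(=O)N[C@@H](C)Cn2ccc(-c3ccc(C#N)c(Cl)c3)n2)cc1`) gives 9050 nM as the only number so far. Compound 2 (`COC(=O)/C=C/C(=O)N[C@@H](C)Cn1ccc(-c2ccc(C#N)c(Cl)c2)n1`) has no place on that scale: its entry reads "not determined" (no result reported) and no potency can be assigned to it.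

The next structure is compound 3 (`C[C@@H](Cn1ccc(-c2ccc(C#N)c(Cl)c2)n1)Nc1ccccn1`). The structural change pyridin-2-yl in place of (2-(methoxycarbonyl)ethenyl)carbonyl on an amine nitrogen puts pyridin-2-yl in place of (2-(methoxycarbonyl)ethenyl)carbonyl on an amine nitrogen, while the rest of the molecule stays as it is.

With no number for compound 2, neither the size nor the direction of this step in this assay can be read from the data. Within the data shown here, the one available reference is compound 1 at 9050 nM and, with nothing yet to argue for a shift, compound 3 is expected to land in the same region, with no difference beyond the usual scatter.

The estimate for compound 3 is 8000 nM with an expected range from 2500 nM to 25000 nM on this read-out.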

Compound 3, half-maximal inhibitory concentration: > 30000 nM
Compound 3 ended at the assay's limit; the forecaster's own chance of this, stated with the estimate: 15%; at least 3.7-fold (0.57 log units) between middle value and limit.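

Within the data shown here, compound 2 carries no number in this assay, and no step from it to compound 3 can be read. Compound 3 stands at a limit, not a number: the limit of > 30000 nM in this assay, at which 1 of the 3 values shown sits. The compounds shown leave open how pyridin-2-yl on the amine nitrogen compares in potency with other groups at that place.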